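A few compounds are considered here, and "the series" means these few. Any claim that something is new, unique, unknown or untested is made for them only; others in the source may bear on it.

Measured compounds:
compound 1, `CC[C@@H]1C(=O)N(C)c2cnc(Nc3ccc(S(=O)(=O)NC4CCCC4)cc3)nc2N1C1CCCC1`, in a functional assay on K562 cells (Homo sapiens) for antiproliferative activity, read by CCK-8 assay, with a stated time of 72 h (on this read-out higher numbers stand for weaker inhibition of growth and lower numbers for stronger inhibition of growth), gives 872 nM
compound 2, `CC[C@@H]1C(=O)N(C)c2cnc(Nc3ccc(S(N)(=O)=O)cc3)nc2N1C1CCCC1`, in this assay gives 470 nM
compound 3, `CC[C@@H]1C(=O)N(C)c2cnc(Nc3ccc(S(=O)(=O)NCC(C)C)cc3)nc2N1C1CCCC1`, in this assay gives 705 nM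

Compound 3 sits second highest of these three numbers, yet a 1.5-fold higher number from compound 2 to compound 3 (0.18 log units; within the scatter) and a 1.2-fold lower number from compound 1 to compound 3 (0.09 log units; within the scatter) both stay within the scatter, so the three compounds cannot be told apart. Compound 4, `CC[C@@H]1C(=O)N(C)c2cnc(Nc3ccc(S(=O)(=O)NCCCO)cc3)nc2N1C1CCCC1`, differs from compound 3 by 2-hydroxyethyl in place of isopropyl on a saturated chain carbon bound to a sulfonamide nitrogen. Among the measured compounds shown here, no measured step changes a sulfonamide substituent into one bearing a hydroxyl, so only the indirect evidence applies: the steps of a 1.9-fold lower number from compound 1 to compound 2 (0.27 log units; within the scatter) and a 1.5-fold higher number from compound 2 to compound 3 (0.18 log units; within the scatter) show that swapping groups on this nitrogen moved this assay little. The expected step is therefore a 1.2-fold lower number from compound 3 to compound 4 (0.07 log units; within the scatter), within the scatter, and compound 4 is estimated at 600 nM, between 300 nM and 1400 nM.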

Compound 4, concentration for 50% growth inhibition: 331 nM
Beside the measured number, compound 4's estimate is 1.8-fold (0.26 log units) above it, and the stated range covers the measured number.
By their numbers in this assay, from the lowest: compounds 4, 2, 3 and 1 (each within the scatter of the next, the first and the last beyond it).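

In this assay, among the compounds shown here, the 3-hydroxypropyl chain gives the first steps on the sulfonamide nitrogen that pass the scatter: a 2.1-fold lower number from compound 3 to compound 4 (0.33 log units; beyond the scatter) and a 2.6-fold lower number from compound 1 to compound 4 (0.42 log units; beyond the scatter) are both modest, while a 1.4-fold lower number from compound 2 to compound 4 (0.15 log units; within the scatter) stays within it. A chain ending in a hydroxyl can thus be told apart from isobutyl and cyclopentyl on this nitrogen, but not from plain hydrogen. Nothing here explains why.

The compounds shown leave open whether the hydroxyl or the chain carrying it matters, and how a methyl ether, an amine, a carboxylic acid, or a shorter or longer chain would compare.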